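The source may hold more compounds than are shown below. What is called first, only, known or untested is meant among the compounds shown, and "the series" means these compounds.

Measured in a toxicity assay on THP-1 cells (Homo sapiens) for inhibition (on this read-out lower numbers stand for higher toxicity in this test and higher numbers for lower toxicity in this test), each value being a limit of the assay:
Compound 1 `COc1ccc(-c2cnc(NC(=O)c3ccc(Br)cc3)n2C)cc1`: > 100000 nM
Compound 2 `COc1ccc(-c2cnc(NC(=O)c3ccc(C)cc3)n2C)cc1`: > 100000 nM
Compound 3 `COc1ccc(-c2cnc(NC(C)=O)n2C)cc1`: > 100000 nM

In this assay compound 3 gives only a limit, > 100000 nM. It shares that position with the other two compounds, as the series shows (the limit of > 100000 nM in this assay, at which 3 of the 3 values shown sit). Compound 4 `COc1ccc(-c2cnc(NC(=O)c3cccc(OC)c3)n2C)cc1` departs from compound 3 by one change (3-methoxyphenyl in place of methyl on a carbonyl carbon), with 3-methoxyphenyl in place of methyl on a carbonyl carbon.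

The closest measured changes also occur on that carbonyl carbon, but run the other way, with methyl replacing 4-bromophenyl or 4-methylphenyl. These are a step that the two limits leave unreadable from compound 1 to compound 3 and a step that the two limits leave unreadable from compound 2 to compound 3. The change of methyl in place of bromo on an aromatic carbon is a step that the two limits leave unreadable from compound 1 to compound 2. None of these gives a size, so the data offer no sign of a shift with either group on the carbonyl carbon. No step beyond the scatter is therefore expected in this assay, and another limit is the likeliest report. The expected change is a number no higher from compound 3 to compound 4 (the limit leaves the size open). The estimated value for compound 4 is 100000 nM, with an expected range from 40000 nM to 200000 nM.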

Compound 4, half-maximal cytotoxic concentration: > 100000 nM
Compound 4: a limit, no number; the forecaster's own chance of this, stated with the estimate: 90%; the middle value lies on the limit itself.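

In this assay compound 4 gives > 100000 nM, a limit of the assay and not a number. The steps to compound 4 from compound 1, compound 2 and compound 3 cannot be read. The compounds shown leave open whether any group on the carbonyl carbon gives a measurable value in this assay.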